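Urea in place of acetamide on the iodophenyl sulfonate

This account rests on a few compounds, and the source may have more. Where it says the series, first, only, none or still open, it means among the compounds named here.

In a functional assay on HT-1080 cells (Homo sapiens) for antiproliferative activity, read by sulforhodamine B assay, with a stated time of 48 h (a higher number here means a weaker inhibitor, a lower number a stronger inhibitor), compound 3 `CC(=O)Nc1ccc(S(=O)(=O)Oc2ccccc2I)cc1` gives 17000 nM, the highest of the three numbers measured, though its gap to compound 1 `CCCCCC(=O)Nc1cccc(S(=O)(=O)Oc2ccccc2C(C)C)c1`, which gives 11000 nM, lies within the scatter. Compound 2 `CC(C)c1ccccc1OS(=O)(=O)c1cccc(NC(=O)CCl)c1` gives 780 nM, and the step of a 14-fold lower number from compound 1 to compound 2 (1.15 log units; beyond the scatter) is the only one measured; it changes a chain on the amide carbonyl, not the pattern seen in compound 4. Compound 4 `CCCCCNC(=O)Nc1ccc(S(=O)(=O)Oc2ccccc2I)cc1` differs from compound 3 by pentylamino in place of methyl on a carbonyl carbon. Compound 1 carries a longer acyl chain than compound 3 and sits within the scatter of it, so no step beyond the scatter is expected. Compound 4 is estimated at 12000 nM, between 4000 nM and 40000 nM, meaning an expected step of a 1.4-fold lower number from compound 3 to compound 4 (0.15 log units; within the scatter).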

Compound 4, half-maximal inhibitory concentration: 6900 nM
Compound 4: middle estimate off by 1.7-fold (0.24 log units), on the high side; the measured number falls inside the stated range.
By their numbers in this assay, from the lowest: compound 2; then compounds 4, 1 and 3 (each within the scatter of the next, the first and the last beyond it).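

Pentylamino in place of methyl on a carbonyl carbon gives a 2.5-fold lower number from compound 3 to compound 4 (0.39 log units; beyond the scatter) in this assay. At this position, then, an acetyl group can give way to the much larger pentylcarbamoyl group, and the number still falls, though only modestly. Nothing measured here accounts for this shift.

The compounds shown leave open whether the step belongs to the added nitrogen or to the pentyl chain, which a methylamino group or a longer chain at this carbonyl carbon would separate. They also leave open how a chloromethyl group there would behave on the core of compound 3.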